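This account rests on a few compounds, and the source may have more. Where it says the series, first, only, none or still open, it means among the compounds named here.

Measured compounds, with activity in a functional assay on SK-MEL-2 cells (Homo sapiens) for inhibition, read by sulforhodamine B assay, with a stated time of 48 h, tested at 0.1 uM; on this read-out lower numbers stand for a stronger effect and higher numbers for a weaker effect at the one concentration tested:
compound 1 `COc1cc(Cl)cc(-c2nn(-c3cccc(NC(=O)Nc4ccc(Cl)c(C(F)(F)F)c4)c3)cc2-c2ccncc2)c1`, 52%
compound 2 `COc1cc(Cl)cc(-c2nn(-c3cccc(NC(=O)Nc4ccc(Cl)c(Cl)c4)c3)cc2-c2ccncc2)c1`, 54%
compound 3 `COc1cc(Cl)cc(-c2nn(-c3cccc(NC(=O)Nc4cccc(C(F)(F)F)c4)c3)cc2-c2ccncc2)c1`, 55%

Compound 3 carries the highest of the three numbers, but the steps of a number 1 percentage points higher from compound 2 to compound 3 (within the scatter) and a number 3 percentage points higher from compound 1 to compound 3 (within the scatter) are both within the scatter, as is a number 2 percentage points higher from compound 1 to compound 2 (within the scatter); the three measured compounds are indistinguishable on this read-out. Compound 4 `COc1cc(Cl)cc(-c2nn(-c3cccc(NC(=O)c4cccc(C(F)(F)F)c4)c3)cc2-c2ccncc2)c1` differs from compound 3 by 3-(trifluoromethyl)phenyl in place of (3-(trifluoromethyl)phenyl)amino on a carbonyl carbon. Within the data shown here, no measured step touches this carbonyl carbon; all three alter only the distal aryl substituents, and all are within the scatter, so they give no direction for the change at hand. The expected step of a number 5 percentage points higher from compound 3 to compound 4 (within the scatter) is therefore small and uncertain. Compound 4 is estimated at 60%, in the range 45% to 80%.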

Compound 4, a percentage reported as activity, at one concentration (the size of the read-out at that concentration, not a potency): 95%
Beside the measured number, compound 4's estimate is 35 percentage points below it; measured number above the stated range.
By their numbers in this assay, from the lowest: compounds 1, 2 and 3 (each within the scatter of the next); then compound 4.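

In this assay, among these compounds, exchanging (3-(trifluoromethyl)phenyl)amino for 3-(trifluoromethyl)phenyl on the carbonyl carbon gives a number 40 percentage points higher from compound 3 to compound 4 (beyond the scatter), the first step beyond the scatter. The steps of a number 41 percentage points higher from compound 2 to compound 4 (beyond the scatter) and a number 43 percentage points higher from compound 1 to compound 4 (beyond the scatter) are also large, so this position weighs far more than the aryl substituent changes, which all stayed within the scatter. Nothing available explains this loss of effect.

Still open, going by these compounds, is whether the amino nitrogen itself is required: a methylene group or a methylamino group on this carbonyl carbon would separate the presence of the nitrogen from that of the amide hydrogen.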